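A Halogen Swap on the Aryl Arm of a Shared Core

A few compounds are considered here, and "the series" means these few. Any claim that something is new, unique, unknown or untested is made for them only; others in the source may bear on it.

The set shares one core, shown in compound 1 `COc1ccc(C(=O)/C=C/c2cccc(F)c2)c2c1C=CC(C)(C)O2`. In a functional assay on K562 cells (Homo sapiens) for antiproliferative activity, read by MTT assay, with a stated time of 24 h (a higher number here means a weaker inhibitor, a lower number a stronger inhibitor), compound 1 gives > 10000 nM, which is a limit of the assay and not a number. Compound 2 `COc1ccc(C(=O)/C=C/c2ccc3ccccc3c2)c2c1C=CC(C)(C)O2` gives 3670 nM in this assay. Compound 3 `COc1ccc(C(=O)/C=C/c2ccc(OC)c(OC)c2OC)c2c1C=CC(C)(C)O2` in this assay gives > 10000 nM, again a limit rather than a number. Among the measured compounds shown here, compound 1 thus stands at the limit of > 10000 nM in this assay, at which 2 of the 3 values shown sit, and no measured step between two compounds of the set is available to size the effect of a single change. Compound 4 `COc1ccc(C(=O)/C=C/c2ccccc2Cl)c2c1C=CC(C)(C)O2` differs from compound 1 in one place: 2-chlorophenyl in place of 3-fluorophenyl on a double-bonded chain carbon bound to a double-bonded chain carbon. For the measured compounds named here, with no measured pair differing in one place, the size of this step is open; the expectation is a step within the scatter or a modest one either way, and with compound 1 at a limit only a move toward lower numbers could be seen. Compound 4 is expected to give 8000 nM in this assay, within 3000 nM to 30000 nM. The step this estimate implies is expected to be an at least 1.2-fold lower number from compound 1 to compound 4 (0.09 log units; that floor lies within the scatter).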

Compound 4, half-maximal inhibitory concentration: > 10000 nM
Compound 4: no number, only a limit; the forecaster's own chance of this, stated with the estimate: 55%; middle value at least 1.2-fold (0.09 log units) away from the limit.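

In this assay compound 4 gives > 10000 nM, a limit of the assay and not a number. Compound 1 also stands at a limit, and the step between compound 1 and compound 4 cannot be read. The compounds shown leave open how 2-chlorophenyl and 3-fluorophenyl compare in this assay, with most values at one limit: the limit of > 10000 nM in this assay, at which 3 of the 4 values shown sit.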